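The source may report more compounds than this note shows. Statements on the series, on what has been measured and on what is new or still open speak of the compounds shown alone.

Going by the values given here, compound 1 `C[C@@H]1CCCN1c1c(C#N)c2c(N)nc(Nc3cn(C)nc3C(F)(F)F)nc2n1C` is one of two compounds measured in an assay on isolated protein for inhibition of Leucine-rich repeat serine/threonine-protein kinase 2 variant G2019S (Homo sapiens), read by TR-FRET and LanthaScreen, with stated times of 50 min and 30 min, in the presence of a further agent that is not named here (a lower number here means a stronger inhibitor, a higher number a weaker inhibitor), where compound 1 gives 358 nM. This is the highest of the two numbers. The other compound, compound 2 `Cc1nn(CC(C)(C)O)cc1Nc1nc(N)c2c(C#N)c(N3CCC[C@H]3C)n(C)c2n1`, gives 42 nM in this assay, a lower number that lies beyond the scatter of repeated measurement, so compound 2 is clearly the stronger inhibitor of the pair. Among the compounds with values here, no single-point step between these two measured compounds is available, since they differ in more than one place.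

The unmeasured compound 3 `C[C@@H]1CCCN1c1c(C#N)c2c(N)nc(Nc3cnn(C)c3)nc2n1C` is made from compound 1 by one change: hydrogen in place of trifluoromethyl on an aromatic carbon. The trifluoromethyl leaves and a hydrogen enters on an aromatic carbon of the five-membered aromatic ring with two nitrogens, next to the ring nitrogen.

Given that compound 2, which carries a smaller group at this ring position, gives 42 nM in this assay, compound 3 is expected to land somewhat below compound 1, with an estimated step of a 2.8-fold lower number from compound 1 to compound 3 (0.44 log units; beyond the scatter) toward stronger inhibition. The estimate for compound 3 in this assay is 130 nM, within a range from 40 nM to 420 nM.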

Compound 3, half-maximal inhibitory concentration: 5 nM
Compound 3: the middle estimate sits 26-fold (1.41 log units) above what was measured; the measured number lies below the stated range.
By their numbers in this assay, from the lowest: compound 3; then compound 2; then compound 1.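

In this assay, going by these compounds alone, hydrogen in place of trifluoromethyl on this aromatic carbon gives a 72-fold lower number from compound 1 to compound 3 (1.85 log units; beyond the scatter), the first reading of this position with everything else held fixed, since the two earlier compounds differ in more than one place. It shows that the shared core needs no substituent on this carbon for strong inhibition: with the plain 1-methyl-1H-pyrazol-4-yl group, compound 3 reaches 5 nM, while trifluoromethyl at this place accounts for a large loss of inhibition in compound 1. Nothing measured on these compounds explains why the step is so large.

On these data alone, with only hydrogen and trifluoromethyl compared directly at this carbon, it remains open whether a chlorine atom, a methoxy group or an ethyl group here would keep a number close to that of compound 3 or move it toward that of compound 1. As far as these compounds go, it is also open whether the exchange would bring a step of similar size if a longer chain, such as a propyl group, replaced the methyl group on the ring nitrogen.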